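The source may report more compounds than this note shows. Statements on the series, on what has been measured and on what is new or still open speak of the compounds shown alone.

Measured so far:
- compound 1, `COc1cc(C(C)C(=O)NCc2ccc(C(F)(F)F)nc2N2CCC(C)CC2)cc(OC)c1N`, 21 nM
- compound 2, `CC1CCN(c2nc(C(F)(F)F)ccc2CNC(=O)C(C)c2cc(Cl)c(N)c(Cl)c2)CC1`, 2.4 nM
- compound 3, `CC1CCN(c2nc(C(F)(F)F)ccc2CNC(=O)C(C)c2ccc(NC(=O)C(C)(C)C)c(F)c2)CC1`, 51.9 nM

In an assay on cells for antagonist activity at transient receptor potential cation channel subfamily V member 1 (Homo sapiens), read by FLIPR and calcium flux, with a stated time of 6 min (a higher number here means a weaker inhibitor, a lower number a stronger inhibitor), compound 3 gives the highest number of the three, so it is the weakest inhibitor shown: compound 1 sits somewhat below it, and compound 2 lies much further down. Among the compounds with values here, the only step measured between two compounds that differ in one place is an 8.8-fold lower number from compound 1 to compound 2 (0.94 log units; beyond the scatter), and that step changes the substituents on the aromatic ring that carries the amide-bearing chain, not the acyl group on the ring nitrogen.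

Compound 4, `CC1CCN(c2nc(C(F)(F)F)ccc2CNC(=O)C(C)c2ccc(NC(=O)c3ccccc3)c(F)c2)CC1`, is compound 3 with one change: phenyl in place of tert-butyl on a carbonyl carbon. Within the data shown here, no measured pair shows what swapping groups at this position does; the change in the step from compound 1 to compound 2 sits on a different part of the molecule and does not bear on it directly. With nothing to point in either direction, the expectation for compound 4 in this assay is a step of no more than scatter size, a 1.0-fold lower number from compound 3 to compound 4 (0.02 log units; within the scatter), in no settled direction.

Compound 4 is therefore expected to give about 50 nM in this assay, within a range from 18 nM to 140 nM.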

Compound 4, inhibition constant: 7.4 nM
Compound 4: the middle estimate sits 6.8-fold (0.83 log units) above what was measured; measured number outside the range, below it.
By their numbers in this assay, from the lowest: compound 2; then compound 4; then compound 1; then compound 3.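

In this assay, within the data shown here, the group on this carbonyl carbon clearly matters: phenyl in place of tert-butyl gives a 7.0-fold lower number from compound 3 to compound 4 (0.85 log units; beyond the scatter), the first measured step at this position of the molecule. The swap replaces a group of 4 heavy atoms with one of 6 heavy atoms and adds a six-membered aromatic ring of carbon only, while the counts of hydrogen-bond donors and acceptors and the net charge stay the same, so a stronger inhibitor here does not depend on any change in those counts. No measurement at hand accounts for the size or direction of this step.

On these data alone, with only tert-butyl and phenyl to compare on this carbonyl carbon, it remains open whether the step follows the aromatic ring itself or simply the larger number of carbon atoms, a question that cyclohexyl, with six carbons and no aromatic ring, could help to separate. As far as these compounds go, how a substituent on the phenyl ring, such as a methoxy group or a chlorine, or a ring containing nitrogen such as pyridyl, would behave at this position also remains unknown.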